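This account rests on a few compounds, and the source may have more. Where it says the series, first, only, none or still open, it means among the compounds named here.

The measured compounds:
Compound 1, `COC(=O)c1ccc(OCCCCOc2ccc(C(=O)CC3CCCC3)c(O)c2C)cc1`: in an assay on HEK293 cells for positive allosteric modulation of metabotropic glutamate receptor 2 (Rattus norvegicus), read by thallium flux, with a stated time of 2.5 min (on this read-out lower numbers stand for an effect already at smaller amounts and higher numbers for an effect only at larger amounts of compound), compound 1 gives "not determined" (no result reported).
Compound 2, `Cc1c(OCCCCOc2ccc(C(=O)O)cc2Cl)ccc(C(=O)CC2CCCC2)c1O`: in this assay compound 2 gives 237 nM.
Compound 3, `Cc1c(OCCCCOc2ccc(F)c(C(=O)O)c2)ccc(C(=O)C(C)C)c1O`: in this assay compound 3 gives 171 nM.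

Going by the values given here, only two numbers exist here. Compound 3 holds one of them and compound 2 the other, and the gap between the two lies within the scatter, so nothing separates them. Compound 1 has no result at all.

Compound 4, `Cc1c(OCCCCOc2ccc(F)c(C(=O)O)c2)ccc(C(=O)CC2CCCC2)c1O`, has not been measured yet. It differs from compound 3 in a single place: cyclopentylmethyl in place of isopropyl on a carbonyl carbon. Among the compounds with values here, no step between measured compounds covers this exchange on its own. Compound 2 does carry a cyclopentylmethyl group on its carbonyl carbon, though on a different acid-bearing ring, and in this assay compound 2 gives 237 nM, which is within the scatter of what compound 3 shows. The step of a 1.1-fold higher number from compound 3 to compound 4 (0.05 log units; within the scatter) is therefore expected to stay within the scatter, in no clear direction. Compound 4 is expected to give about 190 nM in this assay, with a range from 80 nM to 450 nM.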

Compound 4, half-maximal effective concentration: 699 nM
The estimate for compound 4 lay 3.7-fold (0.57 log units) below the measured number; measured number outside the range, above it.
By their numbers in this assay, from the lowest: compounds 3 and 2 (each within the scatter of the next); then compound 4.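

In this assay, going by these compounds alone, cyclopentylmethyl in place of isopropyl on a carbonyl carbon gives a 4.1-fold higher number from compound 3 to compound 4 (0.61 log units; beyond the scatter), so this position responds to the exchange by a margin beyond the scatter, which the earlier compounds could not show. The group on the other end of the molecule matters as well: with cyclopentylmethyl kept, 3-carboxy-4-fluorophenyl in place of 4-carboxy-2-chlorophenyl gives a 2.9-fold higher number from compound 2 to compound 4 (0.47 log units; beyond the scatter), also beyond the scatter. Nothing in the data shown explains either step.

The compounds shown leave open how the number moves with other groups on this carbonyl carbon, such as an ethyl or a cyclohexylmethyl group. They also leave open whether the exchange of isopropyl for cyclopentylmethyl gives a step of similar size when the acid-bearing group is 4-carboxy-2-chlorophenyl.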